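A few compounds are considered here, and "the series" means these few. Any claim that something is new, unique, unknown or untested is made for them only; others in the source may bear on it.

Of the compounds shown here, two from the series have been tested in a functional assay on SMMC-7721 cells (Homo sapiens) for antiproliferative activity, read by MTT assay, with a stated time of 72 h; a lower number here means a stronger inhibitor, a higher number a weaker inhibitor. Compound 1, whose structure is `C#CCSc1nc(Sc2nc3ccccc3s2)c(C#N)c(-c2cc(OC)c(OC)c(OC)c2)n1`, reached only the limit of the assay, giving > 20000 nM, so no number for it is known; it is one of the compounds that sit at this limit, (the limit of > 20000 nM in this assay, at which 1 of the 2 values shown sits). Compound 2, with the structure `C#CCSc1nc(Sc2nnnn2CCN(C)C)c(C#N)c(-c2ccc(Cl)cc2)n1`, gave a measured value of 7340 nM in this assay. Going by the values given here, no step is computed between compound 1 and compound 2, since they differ in more than one place, and their values can only be set side by side.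

Compound 3, with the structure `C#CCSc1nc(Sc2nc(C)c(C)s2)c(C#N)c(-c2cc(OC)c(OC)c(OC)c2)n1`, has not yet been measured. It differs from compound 1 in a single place, (4,5-dimethyl-1,3-thiazol-2-yl in place of 1,3-benzothiazol-2-yl on a sulfur). Among the compounds with values here, with compound 1 known only as a limit, there is no measured step to lean on, and the change is expected to move this assay by no more than the usual scatter in either direction. Compound 3 is therefore expected to give about 20000 nM in this assay, in a range from 6000 nM to 60000 nM, which means an expected step of a number no higher from compound 1 to compound 3 (the limit leaves the size open).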

Compound 3, half-maximal inhibitory concentration: > 20000 nM
Compound 3 was reported as a limit (the forecaster's own chance of this, stated with the estimate: 55%); the middle value sits exactly at the limit.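

Compound 1 and compound 3 are both reported only as a limit, so no step between them can be read in this assay: the limit of > 20000 nM in this assay, at which 2 of the 3 values shown sit.

The compounds shown leave open whether 4,5-dimethyl-1,3-thiazol-2-yl in place of 1,3-benzothiazol-2-yl on a sulfur changes the antiproliferative activity at all.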